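This account rests on a few compounds, and the source may have more. Where it says the series, first, only, none or still open, it means among the compounds named here.

Measured so far in an ADME assay on L1210/0 cells (Mus musculus) for cytotoxicity, with a stated time of 48 h; a lower number here means a stronger inhibitor, a higher number a weaker inhibitor:
Compound 1 `CC1(C)[C@@H](Cn2cnc3c(Cl)nc(N)nc32)CC[C@@]1(C)CO`: 50000 nM
Compound 2 `O=c1[nH]c(=O)n(COCCO)cc1/C=C/Br`: > 200000 nM
Compound 3 `Cc1cn(COCCO)c(=O)[nH]c1=O`: > 200000 nM

Compound 3 gives > 200000 nM, which is a limit of the assay and not a number. Compound 2 gives > 200000 nM, which is likewise a limit. The series therefore rests on (the limit of > 200000 nM in this assay, at which 2 of the 3 values shown sit). For the measured compounds named here, the only true number belongs to compound 1 at 50000 nM, and this compound differs from compound 3 in more than one place.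

The next compound is compound 4 `O=c1[nH]c(=O)n(COCCO)cc1[N+](=O)[O-]`, with nitro in place of methyl on an aromatic carbon. Going by the values given here, the one measured step at that carbon is a step that the two limits leave unreadable from compound 2 to compound 3, with methyl in place of 2-bromoethenyl. It gives no size or direction to carry over to the new group.

With compound 3 at > 200000 nM, compound 4 is expected to remain weak in this assay, and most likely to be reported only as a limit. The expected change is a number no higher from compound 3 to compound 4 (the limit leaves the size open), with no step beyond the scatter and no direction foreseen. For compound 4 the estimated value is 200000 nM, with an expected range from 80000 nM to 300000 nM.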

Compound 4, half-maximal inhibitory concentration: > 200000 nM
Compound 4 gave a limit, no number; the forecaster's own chance of this, stated with the estimate: 85%; the middle value sits exactly at the limit.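

Compound 4, like compound 2 and compound 3, gives a limit and not a number, so no step among these three compounds can be read: the limit of > 200000 nM in this assay, at which 3 of the 4 values shown sit. The compounds shown leave open whether 2-bromoethenyl, methyl and nitro on that aromatic carbon differ at all in this assay, and by how much.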